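This account rests on a few compounds, and the source may have more. Where it says the series, first, only, none or still open, it means among the compounds named here.

Measured in a functional assay on A549 cells (Homo sapiens) for inhibition, read by MTT assay, with a stated time of 48 h, tested at 10 uM; a higher number here means more inhibition of growth at the concentration tested, a lower number less inhibition of growth:
- compound 1 `O=C(/C=C/c1ccc(OCc2cn(Cc3ccccc3F)nn2)cc1)c1ccc(Br)cc1`: 38%
- compound 2 `COc1ccc(C(=O)/C=C/c2ccc(OCc3cn(Cc4ccccc4)nn3)cc2)cc1`: 44%
- compound 3 `COc1ccc(C(=O)/C=C/c2ccc(OCc3cn(Cc4ccc(Br)cc4)nn3)cc2)cc1`: 50%

Compound 3 stands at the top of the three numbers; the gap to compound 2 is within the scatter, the gap to compound 1 is beyond it. Within the data shown here, the only step measured between neighbours that differ in one place is a number 6 percentage points higher from compound 2 to compound 3 (within the scatter), a bromo in place of hydrogen on the benzyl ring attached to the triazole, and it is within the scatter.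

Compound 4 `COc1ccc(C(=O)/C=C/c2ccc(OCc3cn(Cc4ccccc4F)nn3)cc2)cc1` differs from compound 3 by 2-fluorophenyl in place of 4-bromophenyl on a saturated chain carbon bound to an aromatic nitrogen. Among the measured compounds shown here, no measured pair isolates a 2-fluorophenyl against a phenyl or a 4-bromophenyl on this core. Compound 1 carries the 2-fluorobenzyl on the triazole but a bromophenyl ketone instead of the methoxyphenyl ketone, so its lower number cannot be attributed to the benzyl change alone. For the measured compounds named here, the bromo-for-hydrogen step gave little, and removing it again is expected to give back little; the fluorine brings no measured step of its own. In this assay the step from compound 3 to compound 4 is therefore expected to be a number 8 percentage points lower from compound 3 to compound 4 (within the scatter), a small drop within the scatter. Compound 4 is estimated at 42%, in the range 30% to 54%.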

Compound 4, percent growth inhibition at one concentration: 21%
Compound 4: middle estimate off by 21 percentage points, on the high side; measured number outside the range, below it.
By their numbers in this assay, from the lowest: compound 4; then compounds 1, 2 and 3 (each within the scatter of the next, the first and the last beyond it).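

In this assay, among these compounds, the place on a saturated chain carbon bound to an aromatic nitrogen proves more sensitive than the earlier compounds showed: 2-fluorophenyl in place of 4-bromophenyl gives a number 29 percentage points lower from compound 3 to compound 4 (beyond the scatter), and the fluoro substituent taken alone gives a number 23 percentage points lower from compound 2 to compound 4 (beyond the scatter), whereas bromo in place of hydrogen gave only a number 6 percentage points higher from compound 2 to compound 3 (within the scatter). With 2-fluorobenzyl held constant, the substituent on the other aromatic ring also counts, as methoxy in place of bromo on an aromatic carbon gives a number 17 percentage points lower from compound 1 to compound 4 (beyond the scatter). No measurement at hand accounts for either drop.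

As far as these compounds go, it remains open whether the loss belongs to the fluoro substituent itself or to the 2-fluorobenzyl group as a whole, and whether the effect of methoxy in place of bromo carries over to compounds with another benzyl group. A 2-chlorobenzyl group, or a benzyl ring bearing an amine or a carboxylic acid, would extend the reading of this place in this assay.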